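Amino for Chloro on the Aryl Ring of Compound 2

The source may report more compounds than this note shows. Statements on the series, on what has been measured and on what is new or still open speak of the compounds shown alone.

Compounds measured so far:
compound 1, `O=C1CN(/N=C/c2ccc(-c3cccc(C(F)(F)F)c3)o2)C(=O)N1`, 0.05 umol/kg;
compound 2, `O=C1NC(=O)N(/N=C/c2ccc(-c3ccc(Cl)cc3)o2)C1O`, 0.016 umol/kg;
compound 3, `O=C1NC(=O)N(/N=C/c2ccc(-c3cccc(C(F)(F)F)c3)o2)C1O`, 0.096 umol/kg.

In a functional assay on the whole organism (Gastrocnemius, strain Sprague-Dawley) for inhibition, with Rattus norvegicus as the target (on this read-out higher numbers stand for an effect only at larger amounts of compound and lower numbers for an effect already at smaller amounts), compound 2 gives the lowest of the three numbers; compound 1 and compound 3 both lie beyond the scatter above it. Compound 4, `Nc1ccc(-c2ccc(/C=N/N3C(=O)NC(=O)C3O)o2)cc1`, differs from compound 2 by amino in place of chloro on an aromatic carbon. For the measured compounds named here, no measured step touches this position: the single step, a 1.9-fold higher number from compound 1 to compound 3 (0.28 log units; within the scatter), concerns the saturated ring and lies within the scatter. Compound 2 and compound 3, which differ in the aryl group, show that changes there can move the number beyond the scatter. Compound 4 is therefore expected to give a number no lower than compound 2, with a 2.5-fold higher number from compound 2 to compound 4 (0.40 log units; beyond the scatter), estimated at 0.04 umol/kg, between 0.012 umol/kg and 0.13 umol/kg.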

Compound 4, dose for half-maximal effect: 0.039 umol/kg
Compound 4: middle estimate off by 1.0-fold (0.01 log units), on the high side, within the range that was stated.
By their numbers in this assay, from the lowest: compound 2; then compounds 4, 1 and 3 (each within the scatter of the next, the first and the last beyond it).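

For the compounds shown here, the change from 4-chlorophenyl to 4-aminophenyl gives the first measured step on this aromatic carbon: a 2.4-fold higher number from compound 2 to compound 4 (0.39 log units; beyond the scatter). The position therefore responds to exchanging chloro for amino, although the shift is modest and the amino compound remains active at a low dose. Nothing available accounts for the size or direction of this step.

Going by these compounds, it remains open how fluoro, methoxy or nitrile would fare at this position. Also open, on these data alone, is whether amino would produce a similar step on the core of compound 1.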